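From 3-ethynylphenyl to 1-phenylethyl: compound 1 to compound 4

The compounds below may be only part of what the source reports. "The series", "measured", "known", "first", "only" and "open" are said of these compounds alone.

Values in a functional assay on A549 cells (Homo sapiens) for antiproliferative activity, read by MTT assay, with a stated time of 72 h; on this read-out higher numbers stand for weaker inhibition and lower numbers for stronger inhibition:
- compound 1 `C#Cc1cccc(Nc2ncnc3ccc(NC(=O)Nc4ccc(CN5CCN(C)CC5)cc4)cc23)c1`: 5170 nM
- compound 2 `CN1CCN(Cc2ccc(NC(=O)Nc3ccc4ncnc(Nc5cccc(C(=O)N6CCCC6)c5)c4c3)cc2)CC1`: > 10000 nM (a limit, not a number)
- compound 3 `C#Cc1cccc(Nc2ncnc3ccc(NC(=O)Nc4ccc(CN(CC)CC)cc4)cc23)c1`: 2250 nM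

Compound 1 has the higher of the two actual numbers. The gap is a 2.3-fold lower number from compound 1 to compound 3 (0.36 log units; beyond the scatter). Compound 2 gives only a limit.

Compound 4 `C[C@@H](Nc1ncnc2ccc(NC(=O)Nc3ccc(CN4CCN(C)CC4)cc3)cc12)c1ccccc1` carries 1-phenylethyl in place of 3-ethynylphenyl on a nitrogen on an aromatic ring. Among the measured compounds shown here, no measured step makes this exact change. The nearest is an at least 1.9-fold higher number from compound 1 to compound 2 (0.28 log units; that floor lies within the scatter), which alters the group that leaves here. The other, a 2.3-fold lower number from compound 1 to compound 3 (0.36 log units; beyond the scatter), lies elsewhere in the molecule and serves only as a guide to size. Both are small, but the limit of > 10000 nM in this assay, at which 1 of the 3 values shown sits, remains in view for compound 4.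

The expected step is small, a 1.3-fold higher number from compound 1 to compound 4 (0.10 log units; within the scatter), with no move beyond the scatter foreseen. In this assay the estimated value for compound 4 is 6500 nM, expected within 2200 nM to 18000 nM.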

Compound 4, half-maximal inhibitory concentration: > 10000 nM
Compound 4: a limit, no number (the forecaster's own chance of this, stated with the estimate: 30%); middle value at least 1.5-fold (0.18 log units) away from the limit.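

In this assay, 1-phenylethyl in place of 3-ethynylphenyl on this nitrogen gives an at least 1.9-fold higher number from compound 1 to compound 4 (0.28 log units; that floor lies within the scatter). The value of compound 4, > 10000 nM, is a limit and not a number, so this step gives only a floor and does not establish a real difference. Both changes to the 3-ethynylphenyl group, in compound 2 and compound 4, end at the same limit, while the change on the other side of the molecule, in compound 3, still gives a number: the limit of > 10000 nM in this assay, at which 2 of the 4 values shown sit.

Open, going by these compounds, is how a plain benzyl group or a 3-chlorophenyl group on this nitrogen would read in this assay, which would help separate the loss of the ethynyl group from the entry of the stereocentre. Also open, on these data alone, is whether the diethylamino change seen in compound 3 would carry over to a compound bearing 1-phenylethyl.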